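From benzoyl to (4-methylpiperazin-1-yl)sulfonyl on the shared core

The compounds below may be only part of what the source reports. "The series", "measured", "known", "first", "only" and "open" are said of these compounds alone.

In a functional assay on CCRF-CEM cells (Homo sapiens) for inhibition (a higher number here means a weaker inhibitor, a lower number a stronger inhibitor), compound 1 (`C#CCN(Cc1ccc2nc(C)nc(O)c2c1)c1ccc([N+](=O)[O-])cc1`) gives > 4800 nM as a limit of the assay, not a number. Compound 2 (`C#CCN(Cc1ccc2nc(C)nc(O)c2c1)c1ccc(C(=O)c2ccccc2)cc1`) likewise gives > 7700 nM as a limit, so its standing is known only as a limit and no number is available for it.

Compound 3 (`C#CCN(Cc1ccc2nc(C)nc(O)c2c1)c1ccc(S(=O)(=O)N2CCN(C)CC2)cc1`) carries (4-methylpiperazin-1-yl)sulfonyl in place of benzoyl on an aromatic carbon, para to a large group, with the counted change (4-methylpiperazin-1-yl)sulfonyl in place of benzoyl on an aromatic carbon at that place.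

Among the measured compounds shown here, the only measured step at this place is a step that the two limits leave unreadable from compound 1 to compound 2 for benzoyl in place of nitro, so it offers no size to carry over. The data therefore support no expected shift in this assay beyond the scatter, in either direction. This expectation rests on compound 2 at > 7700 nM as a limit, and on the same place having given only limits so far.

The expected change is a step that the limit leaves unreadable from compound 2 to compound 3 as an estimate with no firm direction. For compound 3 the estimated value is 10000 nM with an expected range of 3000 nM to 30000 nM in this reading, and a report as a limit is the likelier outcome.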

Compound 3, half-maximal inhibitory concentration: > 10000 nM
Compound 3 gave a limit, no number (the forecaster's own chance of this, stated with the estimate: 70%); the middle value lies on the limit itself.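

Compound 1, compound 2 and compound 3 are all reported as limits of the assay in this assay, not as numbers, so none of the steps among these three compounds can be read. The compounds shown leave open how nitro, benzoyl and (4-methylpiperazin-1-yl)sulfonyl rank against one another on the shared core in this assay.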